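Swapping an Aryl Group for a Phenethyl Chain

A few compounds are considered here, and "the series" means these few. Any claim that something is new, unique, unknown or untested is made for them only; others in the source may bear on it.

Measured so far in an ADME assay for permeability, using PAMPA, with a stated time of 30 min, at pH 7.4; on this read-out lower numbers stand for lower permeability and higher numbers for higher permeability:
Compound 1 `COc1ccc(-c2ccc3c(NCCCNCc4cccc(OC)c4O)ccnc3c2)cc1` gives 237 10^-6 cm/s.
Compound 2 `Fc1ccc(Oc2ccc3c(NCCCNCc4ccco4)ccnc3c2)cc1` gives 317 10^-6 cm/s.
Compound 3 `COc1ccc(-c2ccc3c(NCCCNCc4cc(F)ccc4OC)ccnc3c2)cc1` gives 237 10^-6 cm/s.

Compound 1 stands level with compound 3, and together they hold the lowest of the three numbers, though the gap to compound 2 lies within the scatter, so no ordering is claimed. The unmeasured compound 4 `COc1cccc(CNCCCNc2ccnc3cc(CCc4ccccc4)ccc23)c1O` differs from compound 1 in one place: phenethyl in place of 4-methoxyphenyl on an aromatic carbon. Within the data shown here, only one measured step bears on it: no change at the digits printed from compound 1 to compound 3 (within the scatter), a change on a saturated chain carbon bound to an amine nitrogen that left the number unmoved. Among the measured compounds shown here, no measured pair alters the group on the core of compound 1, so the footing is thin. With all three numbers within scatter of one another, the step of a 1.1-fold higher number from compound 1 to compound 4 (0.02 log units; within the scatter) is expected to stay within the scatter. Compound 4 is estimated at 250 10^-6 cm/s, between 150 10^-6 cm/s and 400 10^-6 cm/s.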

Compound 4, apparent permeability: 23 10^-6 cm/s
Estimate against measurement, compound 4: 11-fold (1.04 log units) above; measured number below the stated range.
By their numbers in this assay, from the lowest: compound 4; then compounds 1, 3 and 2 (each within the scatter of the next).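

In this assay the group on this aromatic carbon of the core can move the number strongly, with phenethyl in place of 4-methoxyphenyl giving a 10-fold lower number from compound 1 to compound 4 (1.01 log units; beyond the scatter) where the earlier change on a saturated chain carbon gave no change at the digits printed from compound 1 to compound 3 (within the scatter) and nothing more. The two groups match in heavy atoms and in their one aromatic ring, so those counts alone do not track this step. Nothing measured here explains the step.

Still open, from the compounds shown here alone, is whether the oxygen of 4-methoxyphenyl or the chain of phenethyl matters more. Plain phenyl or benzyl on this same carbon would help to separate the two.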